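Removing the acylurea arm from the core: expected potency loss

A few compounds are considered here, and "the series" means these few. Any claim that something is new, unique, unknown or untested is made for them only; others in the source may bear on it.

Measured so far:
- compound 1, `CN(C(=O)NC(=O)c1ccccc1F)c1nc(C(F)(F)F)c(C(=O)N/N=C/c2ccccc2C(F)(F)F)s1`: 10.1 ug/mL
- compound 2, `CNc1nc(C(F)(F)F)c(C(=O)N/N=C/c2ccccc2C(F)(F)F)s1`: > 100 ug/mL
- compound 3, `CN(C(=O)NC(=O)c1ccccc1F)c1nc(C(F)(F)F)c(C(=O)N/N=C/c2ccc(C(F)(F)F)cc2)s1`: 3.97 ug/mL

In a functional assay on HeLa cells (Homo sapiens) for inhibition, read by MTT assay, with a stated time of 72 h (a higher number here means a weaker inhibitor, a lower number a stronger inhibitor), compound 1 gives 10.1 ug/mL. Compound 2 gives > 100 ug/mL, which is a limit of this assay rather than a number. Compound 3 gives 3.97 ug/mL. The step of an at least 9.9-fold higher number from compound 1 to compound 2 (0.99 log units; beyond the scatter) follows the change (hydrogen in place of ((2-fluorophenyl)carbonyl)carbamoyl on a nitrogen on an aromatic ring). The step of a 2.5-fold lower number from compound 1 to compound 3 (0.41 log units; beyond the scatter) follows (4-(trifluoromethyl)phenyl in place of 2-(trifluoromethyl)phenyl on a carbon with a double bond to nitrogen), which is how the cores of compound 3 and compound 1 differ. Compound 4, `CNc1nc(C(F)(F)F)c(C(=O)N/N=C/c2ccc(C(F)(F)F)cc2)s1`, is not yet measured; it differs from compound 3 by hydrogen in place of ((2-fluorophenyl)carbonyl)carbamoyl on a nitrogen on an aromatic ring, the same change as from compound 1 to compound 2, at the same place. Because compound 2 sits at the limit of > 100 ug/mL in this assay, at which 1 of the 3 values shown sits, the step is expected to be large: a 15-fold higher number from compound 3 to compound 4 (1.18 log units; beyond the scatter) is the estimated size. Compound 4 is expected near 60 ug/mL, between 20 ug/mL and 150 ug/mL.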

Compound 4, half-maximal inhibitory concentration: > 100 ug/mL
Compound 4: a limit, no number (the forecaster's own chance of this, stated with the estimate: 55%); at least 1.6-fold (0.22 log units) between middle value and limit.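

Compound 4 gives > 100 ug/mL in this assay, which is a limit and not a number. Replacing the ((2-fluorophenyl)carbonyl)carbamoyl group with hydrogen again weakens inhibition, an at least 25-fold higher number from compound 3 to compound 4 (1.40 log units; beyond the scatter), so the loss carries over from one core to the other. The size of the loss on each core cannot be compared: the same change on two cores in this assay, an at least 9.9-fold higher number (0.99 log units; beyond the scatter) from compound 1 to compound 2 and an at least 25-fold higher number (1.40 log units; beyond the scatter) from compound 3 to compound 4; the limit leaves it open whether they differ

At this nitrogen, the compounds shown offer only the whole ((2-fluorophenyl)carbonyl)carbamoyl group or hydrogen, leaving open how much of that group is needed. An acetyl group or a simple benzoyl group in the same place would help show which part of it matters.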